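Trimming the Ring: From Isopropyl to Bare Hydrogen

This account rests on a few compounds, and the source may have more. Where it says the series, first, only, none or still open, it means among the compounds named here.

Three close analogues share one core and differ only at a single aromatic carbon. In a physicochemical assay for solubility, measured as kinetic solubility (on this read-out higher numbers stand for higher solubility and lower numbers for lower solubility), compound 1 `CCC/N=C1\S/C(=C\c2ccc(O)c(Br)c2)C(=O)N1c1ccccc1C` gives 79000 nM, compound 2 `CCC/N=C1\S/C(=C\c2ccc(O)c(C)c2)C(=O)N1c1ccccc1C` gives 78000 nM, and compound 3 `CCC/N=C1\S/C(=C\c2ccc(O)c(C(C)C)c2)C(=O)N1c1ccccc1C` gives 79000 nM. Compound 3 stands level with compound 1, and all three numbers sit within the scatter of one another. The next step goes to compound 4 `CCC/N=C1\S/C(=C\c2ccc(O)cc2)C(=O)N1c1ccccc1C`: hydrogen in place of isopropyl on an aromatic carbon. The earlier steps shown here at this same carbon were no change at the digits printed from compound 1 to compound 3 (within the scatter) and a 1.0-fold higher number from compound 2 to compound 3 (0.01 log units; within the scatter), so swapping groups there has so far left this assay untouched. A step of no size beyond the scatter is therefore expected, namely no change at the digits printed from compound 3 to compound 4 (within the scatter). For compound 4 the expected value is 79000 nM, with a range from 40000 nM to 160000 nM.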

Compound 4, solubility: 79000 nM
Compound 4: middle estimate and measured number agree at the digits printed; the measured number falls inside the stated range.
By their numbers in this assay, from the lowest: compounds 2, 1, 3 and 4 (each within the scatter of the next).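

Earlier swaps only traded one group for another at this carbon. Compound 4 shows that in this assay the carbon can also carry bare hydrogen, with no group there at all, and the number stays put (no change at the digits printed from compound 3 to compound 4 (within the scatter)), (a 1.0-fold higher number from compound 2 to compound 4 (0.01 log units; within the scatter)) and (no change at the digits printed from compound 1 to compound 4 (within the scatter)). No measurement at hand explains why this position is so flat.

On these data alone, whether the number would stay level with an amine or a carboxylic acid on this carbon remains open. So does whether changes elsewhere on the shared core would move it.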